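The compounds below may be only part of what the source reports. "The series", "measured", "known", "first", "only" and "open" are said of these compounds alone.

Measured so far in a functional assay on the whole organism (Tail, strain ICR) with Mus musculus as the target, in the tail flick test, with a stated time of 150 min, at a dose of 25 umol/kg by the oral route; a lower number here means a weaker effect, a higher number a stronger effect of the compound at the dose given:
- compound 1, `CSCC[C@H](NC(=O)CN(c1nc(Cl)nc2[nH]cnc12)C1CC1)C(=O)OCc1ccccc1`: 17.6%
- compound 2, `NC(=O)CC[C@H](NC(=O)CN(c1nc(Cl)nc2[nH]cnc12)C1CC1)C(=O)O`: 11.4%
- compound 3, `CSCC[C@H](NC(=O)CN(c1nc(Cl)nc2[nH]cnc12)C1CC1)C(=O)O`: 4.14%

Compound 3 holds the lowest of the three numbers. Its distance to compound 1 is given by a number 13.5 percentage points lower from compound 1 to compound 3 (beyond the scatter), a step beyond the scatter; its distance to compound 2 is given by a number 7.3 percentage points lower from compound 2 to compound 3 (within the scatter), a step within the scatter.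

Compound 4, `CC(C)C[C@H](NC(=O)CN(c1nc(Cl)nc2[nH]cnc12)C1CC1)C(=O)O`, is not yet measured. It differs from compound 3 by isopropyl in place of (methylsulfanyl)methyl on a saturated chain carbon, two bonds along the chain from an amide-type nitrogen and a carbonyl carbon.

Among the compounds with values here, only one measured step exchanges a side-chain group on the acid: a number 7.3 percentage points lower from compound 2 to compound 3 (within the scatter), and that stayed within the scatter. The step of a number 13.5 percentage points lower from compound 1 to compound 3 (beyond the scatter) concerns the ester and does not bear on this change. No step beyond the scatter is therefore expected here. The estimated step is a number 3.9 percentage points higher from compound 3 to compound 4 (within the scatter). Compound 4 is expected to give 8%, within a range from 0% to 22%.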

Compound 4, a percentage reported as activity, at one dose (the size of the read-out at that dose, not a potency): 9.13%
The estimate for compound 4 lay 1.1 percentage points below the measured number, and the stated range covers the measured number.
By their numbers in this assay, from the lowest: compounds 3, 4, 2 and 1 (each within the scatter of the next, the first and the last beyond it).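

In this assay, the isopropyl for (methylsulfanyl)methyl exchange gives a number 5 percentage points higher from compound 3 to compound 4 (within the scatter), so at this place on a saturated chain carbon, losing the sulfur and its hydrogen-bond acceptor does not move the acid beyond the scatter. The exchange of carbamoylmethyl for isopropyl gives a number 2.3 percentage points lower from compound 2 to compound 4 (within the scatter), which adds a third side chain to the acids without separating any of them. Nothing available here bears on why these steps are small.

On these data alone, it remains open whether an amine or a phenyl ring on this side chain would give a step beyond the scatter. Also open, as far as these compounds go, is whether a benzyl ester of the isobutyl acid would follow the step of a number 13.5 percentage points lower from compound 1 to compound 3 (beyond the scatter) in reverse.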